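The source may report more compounds than this note shows. Statements on the series, on what has been measured and on what is new or still open speak of the compounds shown alone.

Measured in an ADME assay on MT4 cells (Homo sapiens) for cytotoxicity, read by MTT assay, with a stated time of 96 h; on this read-out higher numbers stand for lower toxicity in this test and lower numbers for higher toxicity in this test:
compound 1 `C/C(=N\NC(N)=O)c1ccc2[nH]c(-c3ccc(Cl)cc3)nc2c1`: "not determined" (no result reported)
compound 2 `C/C(=N\NC(N)=S)c1ccc2[nH]c(-c3ccc(Cl)cc3)nc2c1`: 2000 nM
compound 3 `C/C(=N\NC(N)=S)c1ccc2[nH]c(-c3ccc(C(F)(F)F)cc3)nc2c1`: 2000 nM

Compound 2 gives 2000 nM and stands level with compound 3 at 2000 nM. Compound 1 offers no comparison, with "not determined" (no result reported) as its entry. Compound 4 `C/C(=N\NC(N)=S)c1ccc2[nH]c(-c3ccoc3)nc2c1` has yet to be measured, and it differs from compound 2 on the shared core: furan-3-yl in place of 4-chlorophenyl on an aromatic carbon.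

Within the data shown here, only one measured step bears on this change: no change at the digits printed from compound 2 to compound 3 (within the scatter). That step exchanged chloro for trifluoromethyl and kept the aromatic ring carrying it, whereas here the whole 4-chlorophenyl leaves. Among the measured compounds shown here, it is therefore only a weak guide, and the data hold no measured example of a furan-3-yl group. With no evidence for a shift in either direction, no change beyond the scatter is expected in this assay. The expected step is a 1.3-fold higher number from compound 2 to compound 4 (0.10 log units; within the scatter). For compound 4 the estimated value is 2500 nM, with an expected range from 800 nM to 8000 nM.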

Compound 4, half-maximal cytotoxic concentration: 86000 nM
Beside the measured number, compound 4's estimate is 34-fold (1.54 log units) below it, outside the stated range (above it).
By their numbers in this assay, from the lowest: compounds 2 and 3 (each within the scatter of the next); then compound 4.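

In this assay, among these compounds, the aromatic carbon between two ring nitrogen atoms proves sensitive to what it carries: the change to furan-3-yl gives a 43-fold higher number from compound 2 to compound 4 (1.63 log units; beyond the scatter), the only large step seen here. The earlier step, no change at the digits printed from compound 2 to compound 3 (within the scatter), altered only the group on the six-membered ring and left the number in place, so a large shift appears only once the whole 4-chlorophenyl leaves. Nothing available explains this shift.

The compounds shown leave open whether the shift follows from losing the chloro group, from losing the six-membered ring or from bringing in the furan oxygen, as all of these change together in this one step. Plain phenyl or thiophen-3-yl at this position would begin to separate these possibilities.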